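The source may hold more compounds than are shown below. What is called first, only, known or untested is meant among the compounds shown, and "the series" means these compounds.

Working notes on the series, all read in a toxicity assay on microsomes from liver (Homo sapiens) for metabolic stability, read by LC-MS, using NADPH, tested at 1 uM; on this read-out higher numbers stand for fast clearance and lower numbers for slow clearance. Compound 1 `CCOc1ncc(-c2nc(C(F)(F)F)sc2N2CCN(C(=O)Cn3ccc4cccnc43)[C@H](C)C2)cn1` gives 316 mL.min-1.g-1 and compound 3 `CCOc1ncc(-c2nc(C(F)(F)F)sc2N2CCN(C(=O)Cn3nc(C)cc3C)[C@H](C)C2)cn1` gives 184 mL.min-1.g-1, and a 1.7-fold lower number from compound 1 to compound 3 (0.23 log units; within the scatter) keeps these two within the scatter of each other. Compound 2 `CCOc1ncc(-c2nc(C(F)(F)F)sc2N2CCN(C(=O)Cn3nccc3C)[C@H](C)C2)cn1` gives 65 mL.min-1.g-1, the lowest of the three, with a 4.9-fold lower number from compound 1 to compound 2 (0.69 log units; beyond the scatter) and a 2.8-fold higher number from compound 2 to compound 3 (0.45 log units; beyond the scatter) both beyond the scatter.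

The next compound is compound 4 `CCOc1ncc(-c2nc(C(F)(F)F)sc2N2CCN(C(=O)Cn3ccc(C(F)(F)F)n3)[C@H](C)C2)cn1`, and the change is 3-(trifluoromethyl)-1H-pyrazol-1-yl in place of 3,5-dimethyl-1H-pyrazol-1-yl on a saturated chain carbon bound to a carbonyl carbon. Going by the values given here, no measured compound carries 3-(trifluoromethyl)-1H-pyrazol-1-yl, so the data offer no direct precedent. The closest guide is the methyl in place of hydrogen on an aromatic carbon, a 2.8-fold higher number from compound 2 to compound 3 (0.45 log units; beyond the scatter). This step is modest, and the structural change in it is small. The expectation therefore sits inside the span set by compound 2 and compound 3, with no step beyond the scatter and a slight lean downward. The expected step is a 1.5-fold lower number from compound 3 to compound 4 (0.19 log units; within the scatter). For compound 4 the estimate is 120 mL.min-1.g-1, with an expected range of 50 mL.min-1.g-1 to 290 mL.min-1.g-1.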

Compound 4, intrinsic clearance in microsomes: 20 mL.min-1.g-1
Beside the measured number, compound 4's estimate is 6.0-fold (0.78 log units) above it; measured number below the stated range.
By their numbers in this assay, from the lowest: compound 4; then compound 2; then compounds 3 and 1 (each within the scatter of the next).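

In this assay, going by these compounds alone, the saturated chain carbon bound to a carbonyl carbon takes a group that moves the number below the span of the earlier compounds: 3-(trifluoromethyl)-1H-pyrazol-1-yl in place of 3,5-dimethyl-1H-pyrazol-1-yl gives a 9.2-fold lower number from compound 3 to compound 4 (0.96 log units; beyond the scatter), and in place of 5-methyl-1H-pyrazol-1-yl it gives a 3.3-fold lower number from compound 2 to compound 4 (0.51 log units; beyond the scatter). Heavy-atom count alone does not set the number here, since the groups compared in a 16-fold lower number from compound 1 to compound 4 (1.20 log units; beyond the scatter) both hold 9 heavy atoms. Nothing on hand accounts for the size of these steps.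

As far as these compounds go, the change from 3,5-dimethyl-1H-pyrazol-1-yl to 3-(trifluoromethyl)-1H-pyrazol-1-yl alters more than one substituent, so the share of each remains open. Also open, from the compounds shown here alone, is where the unsubstituted 1H-pyrazol-1-yl, or a pyrazolyl group carrying a nitrile, would fall on this read-out.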